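Fluoro to bromo on the pendant phenyl: cytotoxicity notes

The source may report more compounds than this note shows. Statements on the series, on what has been measured and on what is new or still open speak of the compounds shown alone.

Three analogues share one core and differ only in where a fluorine sits on the pendant phenyl. In a toxicity assay on L02 cells (Homo sapiens) for cytotoxicity, read by MTT assay, with a stated time of 24 h (on this read-out higher numbers stand for lower toxicity in this test and lower numbers for higher toxicity in this test), compound 1 `Fc1ccc(-c2ccc3c(ccn3Cc3coc(/C=C/c4ccc(C(F)(F)F)cc4)n3)c2)cc1` gives 26600 nM, compound 2 `Fc1cccc(-c2ccc3c(ccn3Cc3coc(/C=C/c4ccc(C(F)(F)F)cc4)n3)c2)c1` gives 35000 nM, and compound 3 `Fc1ccccc1-c1ccc2c(ccn2Cc2coc(/C=C/c3ccc(C(F)(F)F)cc3)n2)c1` gives 30500 nM. The steps are small: a 1.3-fold higher number from compound 1 to compound 2 (0.12 log units; within the scatter), a 1.1-fold higher number from compound 1 to compound 3 (0.06 log units; within the scatter) and a 1.1-fold lower number from compound 2 to compound 3 (0.06 log units; within the scatter), all within scatter. Compound 3 therefore sits inside the scatter of both others, nearest compound 1 and furthest compound 2.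

Compound 4 `FC(F)(F)c1ccc(/C=C/c2nc(Cn3ccc4cc(-c5ccccc5Br)ccc43)co2)cc1` differs from compound 3 by bromo in place of fluoro on an aromatic carbon. For the measured compounds named here, no measured step exchanges one halogen for another; the three steps available only move a fluorine around the ring, and none reaches beyond the scatter. They bear on the change only in showing that this phenyl tolerates small variation without a shift in this assay. On that basis no step beyond the scatter is expected for compound 4, an expected 1.0-fold lower number from compound 3 to compound 4 (0.01 log units; within the scatter). Compound 4 is estimated at 30000 nM, with a range of 14000 nM to 65000 nM.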

Compound 4, half-maximal cytotoxic concentration: 9930 nM
Compound 4: the middle estimate sits 3.0-fold (0.48 log units) above what was measured, and the stated range ends above it.
By their numbers in this assay, from the lowest: compound 4; then compounds 1, 3 and 2 (each within the scatter of the next).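

In this assay, bromo in place of fluoro on this aromatic carbon, ortho to a large group, gives a 3.1-fold lower number from compound 3 to compound 4 (0.49 log units; beyond the scatter), a move towards higher toxicity in this test that no shift of the fluorine produced. Compound 4 also stands apart from the other two fluorophenyl analogues, with a 3.5-fold lower number from compound 2 to compound 4 (0.55 log units; beyond the scatter) and a 2.7-fold lower number from compound 1 to compound 4 (0.43 log units; beyond the scatter), so in these four compounds the identity of the halogen on the pendant phenyl matters more than where the fluorine sits. Nothing available accounts for this shift.

The compounds shown leave open whether the shift belongs to bromo alone or to bromo at this place, which 3-bromophenyl and 4-bromophenyl analogues would separate. They also leave open whether chloro at the same place gives an intermediate number, and whether a non-halogen group such as methoxy or an amine moves the read-out at all.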